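The source may hold more compounds than are shown below. What is called first, only, known or untested is meant among the compounds shown, and "the series" means these compounds.

Measured so far in a functional assay on OVCAR-3 cells (Homo sapiens) for inhibition, read by sulforhodamine B assay, with a stated time of 48 h; a higher number here means a weaker inhibitor of growth, a lower number a stronger inhibitor of growth:
compound 1 `CC1=CC[C@H](C(C)(C)N=C=S)CC1` gives > 100000 nM
compound 2 `CC1=CC[C@H](C(C)(C)NC(=S)NN)CC1` gives > 100000 nM
compound 3 `CC1=CC[C@H](C(C)(C)NC(=S)N/N=C/c2ccccc2)CC1` gives 20600 nM

The value of compound 1 is a limit of this assay, not a number. The value of compound 2 is likewise a limit, not a number. Within the data shown here, compound 3 therefore holds the only number in this assay, and it stands on its own, with nothing to rank it against. The step that the two limits leave unreadable from compound 1 to compound 2 cannot be read because both of its ends sit at the limit of > 100000 nM in this assay, at which 2 of the 3 values shown sit.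

Compound 4 `CC1=CC[C@H](C(C)(C)NC(=S)N/N=C/c2ccc(N(C)C)cc2)CC1` is next to be measured. It differs from compound 3 by dimethylamino in place of hydrogen on an aromatic carbon. Among the measured compounds shown here, no measured step touches this aromatic ring; the one step that exists runs between two limits and carries no size. For the measured compounds named here, there is thus no measured step that bears on the change, and nothing here to point to a large move in either direction.

The step from compound 3 to compound 4 is estimated as a 1.4-fold lower number from compound 3 to compound 4 (0.14 log units; within the scatter), not beyond the scatter of this assay. Compound 4 is expected to give 15000 nM in this assay, within a range of 5000 nM to 60000 nM; the range is wide on the side of weaker inhibition because compound 1 and compound 2 sit at the limit of > 100000 nM in this assay, at which 2 of the 3 values shown sit.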

Compound 4, concentration for total growth inhibition: > 100000 nM
Compound 4 was reported as a limit; the forecaster's own chance of this, stated with the estimate: 15%; middle value at least 6.6-fold (0.82 log units) from the limit.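

In this assay compound 4 gives > 100000 nM, which is a limit of the assay and not a number. Dimethylamino in place of hydrogen on an aromatic carbon, para to a large group, gives an at least 4.8-fold higher number from compound 3 to compound 4 (0.68 log units; beyond the scatter); this is the first readable step in the series, and it shows that the aromatic ring of compound 3 does not tolerate every change at this carbon, the move running toward weaker inhibition of growth and lying beyond the scatter. Compound 3 remains the only compound in the series that carries a number, so the series still has no second point to rank it against: the limit of > 100000 nM in this assay, at which 3 of the 4 values shown sit.

The compounds shown rest on this single substituent, so they leave open whether the loss belongs to dimethylamino itself or to any group on this aromatic carbon. A methoxy group, a chlorine or a carboxylic acid at the same place would separate those two readings and would show whether any group can take the number below that of compound 3.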